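Aryl-to-arylpropyl exchange on the ring amine nitrogen

The compounds below may be only part of what the source reports. "The series", "measured", "known", "first", "only" and "open" are said of these compounds alone.

Two compounds of this series have been run in an assay on CHO cells for displacement of a labelled ligand from adenosine receptor A1 (Homo sapiens), read by scintillation counting, with a stated time of 120 min, tested at 10 uM; a higher number here means more inhibition at the concentration tested (going by the name of the read-out), a lower number less inhibition. Compound 1 `Nc1scc(CN2CCN(c3ccc([N+](=O)[O-])cc3)CC2)c1C(=O)c1ccc(Cl)cc1` gives 1%. Going by the values given here, compound 2 `Nc1scc(CN2CCN(c3cccc(F)c3F)CC2)c1C(=O)c1ccc(Cl)cc1` gives 0%, the lowest of the two numbers; its only neighbour is compound 1, and the step of a number 1 percentage points lower from compound 1 to compound 2 (within the scatter) lies within the scatter, so the two stand level. Both numbers sit at the floor of the read-out.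

Compound 3 `Nc1scc(CN2CCN(CCCc3ccc(Cl)cc3)CC2)c1C(=O)c1ccc(Cl)cc1` is not yet measured. It differs from compound 2 as follows: 3-(4-chlorophenyl)propyl in place of 2,3-difluorophenyl on an amine nitrogen in a ring. Among the compounds with values here, the one measured step, from compound 1 to compound 2, exchanged one aromatic ring for another on the same ring nitrogen and changed nothing beyond the scatter; no measured step covers a 3-(4-chlorophenyl)propyl group or any chain in this place. With both measured numbers at the floor, no step beyond the scatter is expected, a number 4 percentage points higher from compound 2 to compound 3 (within the scatter). Compound 3 is therefore estimated at 4%, with a range of -8% to 22% in this assay .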

Compound 3, a percentage reported as inhibition, at one concentration (the size of the read-out at that concentration, not a potency): 0%
The estimate for compound 3 lay 4 percentage points above the measured number; measured number inside the range.
By their numbers in this assay, from the lowest: compounds 2, 3 and 1 (each within the scatter of the next).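

In this assay, a propyl chain between the ring nitrogen and the aromatic ring reads no differently from an aromatic ring set directly on that nitrogen: no change at the digits printed from compound 2 to compound 3 (within the scatter), and a number 1 percentage points lower from compound 1 to compound 3 (within the scatter). The floor of the read-out therefore now covers a 3-(4-chlorophenyl)propyl group as well as the 2,3-difluorophenyl and 4-nitrophenyl groups, so this exchange on the amine nitrogen gives no measurable gain at the concentration tested. Nothing available bears on why these three groups read alike.

Going by these compounds, with all three compounds at the floor, it remains open whether any group at this nitrogen can lift the number at all. A longer chain, a carboxylic acid or an amine at the end of the chain, or a benzoyl group on the ring nitrogen could each test this.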